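The source may report more compounds than this note shows. Statements on the series, on what has been measured and on what is new or still open speak of the compounds shown alone.

In a functional assay on NCI-H460 cells (Homo sapiens) for cytotoxicity, read by MTT assay, with a stated time of 72 h (a lower number here means a stronger inhibitor, a higher number a weaker inhibitor), compound 1 (`CCN1C/C(=C\c2cc(OC)c(OC)c(OC)c2)C(=O)/C(=C/c2cc(OC)c(OC)c(OC)c2)C1`) gives 4900 nM and compound 2 (`CCC(=O)N1C/C(=C\c2cc(OC)c(OC)c(OC)c2)C(=O)/C(=C/c2cc(OC)c(OC)c(OC)c2)C1`) gives 2700 nM on the shared core, so compound 2 stands level with compound 1 within the scatter. Compound 3 (`COc1cc(/C=C2\CN(C(=O)c3ccccc3F)C/C(=C\c3cc(OC)c(OC)c(OC)c3)C2=O)cc(OC)c1OC`) departs from compound 2 on a carbonyl carbon, with 2-fluorophenyl in place of ethyl on a carbonyl carbon as the counted difference, 2-fluorophenyl in place of ethyl. For the measured compounds named here, the only measured step that bears on this (a 1.8-fold lower number from compound 1 to compound 2 (0.26 log units; within the scatter)) lies within the scatter, and it concerns propanoyl in place of ethyl on an amine nitrogen in a ring, a different exchange. Going by the values given here, no measured compound carries 2-fluorophenyl, so the data offer no direction, and no step beyond the scatter is expected in this assay for this change. The expected size is an estimated 1.1-fold lower number from compound 2 to compound 3 (0.03 log units; within the scatter) within the scatter. Compound 3 is estimated at 2500 nM (900 nM to 6500 nM).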

Compound 3, half-maximal inhibitory concentration: 1500 nM
Compound 3: the middle estimate sits 1.7-fold (0.22 log units) above what was measured, within the range that was stated.
By their numbers in this assay, from the lowest: compounds 3, 2 and 1 (each within the scatter of the next, the first and the last beyond it).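

In this assay, the carbonyl carbon on the amine nitrogen in the ring accepts an aromatic group: with 2-fluorophenyl in place of ethyl, compound 3 stays level with compound 2 within the scatter (a 1.8-fold lower number from compound 2 to compound 3 (0.26 log units; within the scatter)). Set against the plain ethyl on the amine nitrogen, however, (2-fluorophenyl)carbonyl gives the only step beyond the scatter in this series, and a modest one (a 3.3-fold lower number from compound 1 to compound 3 (0.51 log units; beyond the scatter)), which propanoyl alone had not shown. Nothing measured here accounts for these numbers.

The compounds shown leave open whether the fluorine matters, as a plain phenyl on the same carbonyl carbon is not among them. They also leave open how a longer chain or an amine at that place would compare with propanoyl and (2-fluorophenyl)carbonyl.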